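Ester to ether exchange at the side-chain oxygen

A few compounds are considered here, and "the series" means these few. Any claim that something is new, unique, unknown or untested is made for them only; others in the source may bear on it.

Measured so far in a functional assay on DU-145 cells (Homo sapiens) for cytotoxicity, read by MTT assay; a lower number here means a stronger inhibitor, a higher number a weaker inhibitor:
compound 1 `CCC(C)(O)CC(=O)O[C@H](CC=C(C)C)C1=CC(=O)c2c(O)ccc(O)c2C1=O` gives 16000 nM
compound 2 `CC[C@](C)(O)CC(=O)O[C@H](CC=C(C)C)C1=CC(=O)c2c(O)ccc(O)c2C1=O` gives 20500 nM
compound 3 `CCCCC(C)(O)CC(=O)O[C@H](CC=C(C)C)C1=CC(=O)c2c(O)ccc(O)c2C1=O` gives 76500 nM

Compound 3 stands at the highest number of the three. The step of a 4.8-fold higher number from compound 1 to compound 3 (0.68 log units; beyond the scatter) and the step of a 3.7-fold higher number from compound 2 to compound 3 (0.57 log units; beyond the scatter) both run toward the longer acyl chain and both lie beyond the scatter, so lengthening the chain weakened the compounds in this assay. The step of a 1.3-fold higher number from compound 1 to compound 2 (0.11 log units; within the scatter) lies within the scatter; the only thing that separates that pair is the fact that one of compounds 1 and 2 is drawn with a defined configuration and the other without, at the place where they differ, and it gives no usable direction.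

Compound 4 `CCC(CO[C@H](CC=C(C)C)C1=CC(=O)c2c(O)ccc(O)c2C1=O)OC` is unmeasured. Against compound 3 it shows (2-methoxybutyl in place of (2-hydroxy-2-methylhexyl)carbonyl on an oxygen on a saturated carbon). The carbonyl and the hydroxyl of the acyl side chain are gone and a shorter, ether-linked chain takes their place. Going by the values given here, none of the measured steps changes the ester itself; they only vary chain length on the acyl side, where shortening went with lower numbers. Because of a 4.8-fold higher number from compound 1 to compound 3 (0.68 log units; beyond the scatter) a somewhat lower number than for compound 3 is expected, with wide uncertainty since the ester-to-ether exchange is unprecedented here. Compound 4 is therefore estimated at 25000 nM, between 6000 nM and 100000 nM, a step of a 3.1-fold lower number from compound 3 to compound 4 (0.49 log units; beyond the scatter) in this assay.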

Compound 4, half-maximal inhibitory concentration: 45700 nM
Compound 4: middle estimate off by 1.8-fold (0.26 log units), on the low side, within the range that was stated.
By their numbers in this assay, from the lowest: compounds 1 and 2 (each within the scatter of the next); then compounds 4 and 3 (each within the scatter of the next).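

The exchange of the acyl side chain for 2-methoxybutyl on an oxygen on a saturated carbon is the only change shown that removes the ester carbonyl, and in this assay it leaves compound 4 level with the longest ester (a 1.7-fold lower number from compound 3 to compound 4 (0.22 log units; within the scatter)). Against the two shorter esters, the ether lies on the weaker side (a 2.2-fold higher number from compound 2 to compound 4 (0.35 log units; beyond the scatter); a 2.9-fold higher number from compound 1 to compound 4 (0.46 log units; beyond the scatter)), so a shorter side chain at this oxygen does not by itself carry the lower numbers seen among the esters, although an acyl group is evidently not required for a measurable cytotoxic effect in this assay. Nothing on hand gives a reason for this result.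

Compound 4 changes the linkage, the hydroxyl and the chain all at once, so their separate contributions remain unresolved; a 2-hydroxybutyl ether, a plain butyl ether or an amide linkage at this position would begin to pull them apart. From the compounds shown here alone, the shared core stays constant in all four compounds, so it also remains open whether the side-chain trends would hold on a core carrying, for example, an amine.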